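A few compounds are considered here, and "the series" means these few. Any claim that something is new, unique, unknown or untested is made for them only; others in the source may bear on it.

Measured in a functional assay for inhibition, with Rattus norvegicus as the target; a lower number here means a stronger inhibitor, a higher number a weaker inhibitor:
- compound 1 `CC(C)(C)/N=c1\c(O)c(O)\c1=N/c1ccc(C#N)cc1`: 560 nM
- compound 2 `CC(C)C(C)/N=c1\c(O)c(O)\c1=N/c1ccc(C#N)cc1`: 1900 nM
- compound 3 `CC(C)(C)C/N=c1\c(O)c(O)\c1=N/c1ccc(C#N)cc1`: > 30000 nM (a limit of the assay, not a number)

Compound 3 has no exact value and stands only at its limit of > 30000 nM. Among the three measured compounds, only compound 3 sits there: the limit of > 30000 nM in this assay, at which 1 of the 3 values shown sits.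

Compound 4 `C/N=c1\c(O)c(O)\c1=N/c1ccc(C#N)cc1` differs from compound 3 by hydrogen in place of tert-butyl on a saturated chain carbon bound to a double-bonded nitrogen, so that neopentyl becomes methyl on the double-bonded nitrogen. Among the measured compounds shown here, no measured step makes this exact change. The nearest evidence is the change of group on that nitrogen: a 3.4-fold higher number from compound 1 to compound 2 (0.53 log units; beyond the scatter), then an at least 53-fold higher number from compound 1 to compound 3 (1.72 log units; beyond the scatter) and an at least 15-fold higher number from compound 2 to compound 3 (1.19 log units; beyond the scatter). These steps show that this group matters greatly, and that losing tert-butyl can cost much. Nothing measured suggests that methyl would recover what neopentyl lost, so little change is expected, and compound 4 will probably stay weak, possibly at the limit. The estimate implies an at least 1.2-fold lower number from compound 3 to compound 4 (0.07 log units; that floor lies within the scatter) as the expected step. For compound 4 the estimate is 25000 nM, with an expected range of 7000 nM to 30000 nM.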

Compound 4, half-maximal inhibitory concentration: > 30000 nM
Compound 4: a limit, no number (the forecaster's own chance of this, stated with the estimate: 55%); at least 1.2-fold (0.07 log units) between middle value and limit.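

In this assay compound 4 gives > 30000 nM, a limit and not a number, so shortening neopentyl to methyl on this double-bonded nitrogen brings back no measurable inhibition. Methyl therefore falls well short of the two groups that do give numbers, with an at least 15-fold higher number from compound 2 to compound 4 (1.19 log units; beyond the scatter) and an at least 53-fold higher number from compound 1 to compound 4 (1.72 log units; beyond the scatter). The step between neopentyl and methyl itself cannot be read, because both compounds sit at the same ceiling: the limit of > 30000 nM in this assay, at which 2 of the 4 values shown sit.

Going by these compounds, how much weaker either compound truly is than that ceiling shows remains unknown. On these data alone, it is also open whether isopropyl, a cyclohexyl ring or a chain ending in an amine on this nitrogen would give a measurable value, and whether any such group could match or pass tert-butyl.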